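The compounds below may be only part of what the source reports. "The series", "measured", "known", "first", "only" and "open" are said of these compounds alone.

Measured in a functional assay on NCI-H460 cells (Homo sapiens) for inhibition, read by MTT assay, with a stated time of 72 h; a lower number here means a stronger inhibitor of growth, a higher number a weaker inhibitor of growth:
- compound 1 `N#C/C(=C\c1ccc(Cl)cc1)C(=O)c1ccc[nH]1` gives 43000 nM.
- compound 2 `N#C/C(=C\c1ccc[nH]1)C(=O)NCc1ccc(Cl)c(Cl)c1` gives only a limit, > 50000 nM.
- compound 3 `COc1ccc(CNC(=O)/C(C#N)=C/c2ccco2)cc1` gives 32000 nM.

Compound 3 holds the lowest of the two numbers shown, with compound 1 at a slightly higher number; that gap lies within the scatter, so no order between the two is claimed. Compound 2 stopped at the limit of > 50000 nM in this assay, at which 1 of the 3 values shown sits.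

Compound 4 `COc1ccc(CNC(=O)/C(C#N)=C/c2ccoc2)cc1` differs from compound 3 by furan-3-yl in place of furan-2-yl on a double-bonded chain carbon bound to a double-bonded chain carbon. Within the data shown here, no measured pair covers a change of this kind, so the step from compound 3 to compound 4 in this assay is expected to be a 1.1-fold higher number from compound 3 to compound 4 (0.05 log units; within the scatter), meaning essentially none beyond the scatter, with a slight lean towards a higher number. On that basis compound 4 is expected to give 36000 nM, between 15000 nM and 90000 nM.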

Compound 4, concentration for 50% growth inhibition: 8000 nM
Estimate against measurement, compound 4: 4.5-fold (0.65 log units) above; measured number below the stated range.
By their numbers in this assay, from the lowest: compound 4; then compounds 3 and 1 (each within the scatter of the next). At a limit, above all of these: compound 2.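

Furan-3-yl in place of furan-2-yl on a double-bonded chain carbon bound to a double-bonded chain carbon gives, in this assay, a 4.0-fold lower number from compound 3 to compound 4 (0.60 log units; beyond the scatter). Among these compounds, this is the first readable step, and it shows that this position responds to a change of furan attachment alone, with heavy atoms, donors and acceptors counted the same. Nothing measured here gives a cause for this step.

From the compounds shown here alone, whether an amine or a carboxylic acid at this position would keep the growth inhibition stays open. Going by these compounds, whether the furan-3-yl gain carries over to other amide substituents is also open.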